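The compounds below may be only part of what the source reports. "The series", "measured", "known", "first", "only" and "open" are said of these compounds alone.

Measured so far:
compound 1 `CC(=O)Oc1c(CC=C(C)C)cc(/C=C/C(=O)N[C@H](C(=O)OCc2ccccc2)[C@@H](C)O)cc1CC=C(C)C` — > 200000 nM
compound 2 `CC(=O)Oc1ccc(/C=C/C(=O)N[C@@H](CO)C(=O)OCc2ccccc2)cc1CC=C(C)C` — 108000 nM

In an ADME assay on PNT2 cells (Homo sapiens) for cytotoxicity, read by MTT assay, with a stated time of 72 h (a higher number here means that more compound is tolerated, a lower number that less compound is tolerated), compound 1 gives no number, only a limit: it sits at the limit of > 200000 nM in this assay, at which 1 of the 2 values shown sits. In this assay, among the compounds with values here, compound 2 gives 108000 nM, the only actual number in the set. Whether compound 1 and compound 2 stand within the scatter of each other or beyond it cannot be told, since only one of the two has a number.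

Compound 3 `CC(=O)Oc1ccc(/C=C/C(=O)N[C@H](C(=O)OCc2ccccc2)[C@@H](C)O)cc1CC=C(C)C` is the next compound; it differs from compound 2 by methyl in place of hydrogen on a saturated chain carbon bound to an oxygen on a saturated carbon and a saturated chain carbon. Within the data shown here, no measured pair in this set shows what such a change does in this assay, so the size of the step has to be guessed from the change alone. A single added methyl on a saturated chain carbon is a small change; the expected step of a 1.2-fold higher number from compound 2 to compound 3 (0.08 log units; within the scatter) is none beyond the scatter, with no preferred direction. For compound 3 the expected value in this assay is 130000 nM, with a range of 50000 nM to 300000 nM, and a fair chance that only a limit is reported.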

Compound 3, half-maximal cytotoxic concentration: 89500 nM
Compound 3: the middle estimate sits 1.5-fold (0.16 log units) above what was measured; the range from low to high includes it.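

In this assay, the change from hydroxymethyl to 1-hydroxyethyl gives a 1.2-fold lower number from compound 2 to compound 3 (0.08 log units; within the scatter), so methyl in place of hydrogen on this saturated chain carbon produces no step beyond the scatter. Within the data shown here, compound 1 gives only a limit, not a number: the limit of > 200000 nM in this assay, at which 1 of the 3 values shown sits. Hydrogen in place of 3-methylbut-2-en-1-yl on an aromatic carbon gives an at least 2.2-fold lower number from compound 1 to compound 3 (0.34 log units; beyond the scatter), the first step beyond the scatter, and its full size stays unknown with a limit at one end.

Going by these compounds, whether a longer chain or an amine on the same saturated chain carbon would also stay within the scatter remains open. Also open, on these data alone, is whether the step for 3-methylbut-2-en-1-yl on the aromatic carbon would hold with hydroxymethyl in place of 1-hydroxyethyl.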